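The source may report more compounds than this note shows. Statements on the series, on what has been measured and on what is new or still open speak of the compounds shown alone.

Measured so far, in a functional assay on HCT-116 cells (Homo sapiens) for antiproliferative activity, read by MTT assay, with a stated time of 48 h; a lower number here means a stronger inhibitor, a higher number a weaker inhibitor:
Compound 1, `O=C(Nc1cc(Sc2ncn[nH]2)c(O)c2ccccc12)c1ccc2ccccc2c1`: compound 1 gives > 100000 nM, which is a limit of the assay and not a number.
Compound 2, `COc1ccc(/C=C/C(=O)Nc2cc(Sc3ncn[nH]3)c(O)c3ccccc23)cc1OC`: compound 2 gives > 100000 nM, again a limit of the assay.
Compound 3, `O=C(Nc1cc(Sc2nncs2)c(O)c2ccccc12)c1ccc(Cl)cc1`: compound 3 gives > 100000 nM, once more a limit of the assay.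

Compound 1 therefore stands nowhere in particular on the numbers shown: its value in this assay is only a limit, and the two other values shown share that limit, as summed up in the limit of > 100000 nM in this assay, at which 3 of the 3 values shown sit. Among the compounds with values here, no step between measured compounds can be read from this, since none of the three gives a number.

Compound 4, `Cc1cccc(C(=O)Nc2cc(Sc3ncn[nH]3)c(O)c3ccccc23)c1`, is the one not yet measured. It differs from compound 1 in a single place: 3-methylphenyl in place of naphthalen-2-yl on a carbonyl carbon. Nothing measured here tells which way such a change moves the read-out in this assay, and all three shared-core compounds sit at the same limit.

In the absence of a measured step, no movement beyond the scatter is expected from compound 1 to compound 4, so compound 4 is estimated at 100000 nM, within 30000 nM to 300000 nM, which is to say a step of a number no higher from compound 1 to compound 4 (the limit leaves the size open) that amounts to no change, with a further limit the most likely report.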

Compound 4, half-maximal inhibitory concentration: > 100000 nM
Compound 4: no number, only a limit; the forecaster's own chance of this, stated with the estimate: 85%; the middle value lies on the limit itself.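

In this assay compound 4 gives > 100000 nM as a limit of the assay and not a number. Within the data shown here, the value of compound 1 is a limit too, so no step from compound 1 to compound 4 can be read. The compounds shown leave open how any change on the shared core moves antiproliferative activity, because none of them gives a number: the limit of > 100000 nM in this assay, at which 4 of the 4 values shown sit.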